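Compound 3 and Its 2,4-Difluorophenyl Counterpart

The compounds below may be only part of what the source reports. "The series", "measured", "known", "first", "only" and "open" are said of these compounds alone.

In a functional assay on ACHN cells (Homo sapiens) (on this read-out lower numbers stand for stronger inhibition of growth and higher numbers for weaker inhibition of growth), compound 3 (`O=S(=O)(/C=C/c1ccc(Cl)cc1Cl)Cc1ccc(Nc2ncnc3ccccc23)cc1`) gives 100 nM, the second highest of three numbers. Compound 1 (`O=S(=O)(/C=C/c1ccc(F)cc1)Cc1ccc(Nc2ncnc3ccccc23)cc1`) gives 10 nM, and compound 2 (`O=S(=O)(/C=C/c1ccc(Cl)c(Cl)c1)Cc1ccc(Nc2ncnc3ccccc23)cc1`) gives 28000 nM. Compound 4 (`O=S(=O)(/C=C/c1ccc(F)cc1F)Cc1ccc(Nc2ncnc3ccccc23)cc1`) carries 2,4-difluorophenyl in place of 2,4-dichlorophenyl on a double-bonded chain carbon bound to a double-bonded chain carbon. Among the compounds with values here, no measured step makes this exact exchange. The nearest evidence is the modest 10-fold higher number from compound 1 to compound 3 (1.00 log units; beyond the scatter), which links 4-fluorophenyl to 2,4-dichlorophenyl. The large 2800-fold higher number from compound 1 to compound 2 (3.45 log units; beyond the scatter) and a 280-fold lower number from compound 2 to compound 3 (2.45 log units; beyond the scatter) show that this series can move sharply, so the range stays wide. A modest move to a lower number is expected in this assay, an estimated 3.3-fold lower number from compound 3 to compound 4 (0.52 log units; beyond the scatter). For compound 4 the estimate is 30 nM, with an expected range of 6 nM to 200 nM.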

Compound 4, concentration for 50% growth inhibition: 31000 nM
Compound 4: middle estimate off by 1000-fold (3.01 log units), on the low side; the whole stated range lies below it.
By their numbers in this assay, from the lowest: compound 1; then compound 3; then compounds 2 and 4 (each within the scatter of the next).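

In this assay, 2,4-difluorophenyl in place of 2,4-dichlorophenyl at this place is no minor exchange: it gives a 310-fold higher number from compound 3 to compound 4 (2.49 log units; beyond the scatter) and shows that the outcome depends on the halogen as well as on where it sits. Fluoro in place of hydrogen on an aromatic carbon gives a 3100-fold higher number from compound 1 to compound 4 (3.49 log units; beyond the scatter) as a large step, while a 1.1-fold higher number from compound 2 to compound 4 (0.04 log units; within the scatter) stays within the scatter despite the different halogens and pattern. No measurement shown explains these steps.

As far as these compounds go, it remains open how an unsubstituted phenyl would behave at this place. A pyridine ring there is equally unresolved.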